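Cyclohexyl to phenyl on the ring nitrogen of compound 3

The compounds below may be only part of what the source reports. "The series", "measured", "known", "first", "only" and "open" are said of these compounds alone.

Measured compounds:
compound 1 `COc1cc(N(C)CCCO)ccc1/C=C1\C(=O)N(c2ccccc2)C(=S)N1C` 2790 nM
compound 2 `CCN(CC)c1ccc(/C=C2\C(=O)N(c3ccccc3)C(=S)N2C)c(O)c1` 910 nM
compound 3 `CN1C(=S)N(C2CCCCC2)C(=O)/C1=C\c1ccc(N(C)CCCO)cc1O` 3390 nM

In an assay on isolated protein for inhibition of NADPH oxidase 2 (Homo sapiens), read by chemiluminescence, in the presence of a further agent that is not named here (a lower number here means a stronger inhibitor, a higher number a weaker inhibitor), compound 3 gives 3390 nM, the highest of the three numbers. Compound 1, with 2790 nM, lies within the scatter of compound 3. Compound 2 gives 910 nM, and the gap from compound 3 to compound 2 lies beyond the scatter.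

Compound 4 `CN1C(=S)N(c2ccccc2)C(=O)/C1=C\c1ccc(N(C)CCCO)cc1O` has not yet been measured in this assay. It differs from compound 3 in one place: phenyl in place of cyclohexyl on an amide-type nitrogen in a ring. Compounds 1 and 2 both carry a phenyl at that ring nitrogen, and compound 4 shares its hydroxy group on the benzylidene ring with compound 2, which is the strongest of the measured set. Among the measured compounds shown here, no measured pair isolates the cyclohexyl-to-phenyl change, so the size of the step is uncertain.

Compound 4 is expected to give 1500 nM, within a range of 500 nM to 4500 nM. The expected step of a 2.3-fold lower number from compound 3 to compound 4 (0.35 log units; beyond the scatter) is a modest move toward a lower number, possibly not beyond the scatter.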

Compound 4, half-maximal inhibitory concentration: 6330 nM
Compound 4: the middle estimate sits 4.2-fold (0.63 log units) below what was measured; the measured number lies above the stated range.
By their numbers in this assay, from the lowest: compound 2; then compounds 1, 3 and 4 (each within the scatter of the next, the first and the last beyond it).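

In this assay, the step of a 1.9-fold higher number from compound 3 to compound 4 (0.27 log units; within the scatter) means that cyclohexyl and phenyl on this amide-type nitrogen in a ring cannot be told apart, so the aromatic ring brings no measurable gain at this position. The other two steps carry more weight, with (3-hydroxypropyl)(methyl)amino in place of diethylamino on an aromatic carbon giving a 7.0-fold higher number from compound 2 to compound 4 (0.84 log units; beyond the scatter) as the larger of them. Hydrogen in place of methyl on an oxygen on an aromatic ring gives a 2.3-fold higher number from compound 1 to compound 4 (0.36 log units; beyond the scatter) as a modest change in the same direction.

Nothing available here accounts for any of these steps. Going by these compounds, whether a benzyl group on the ring nitrogen, or a carboxylic acid in place of the hydroxyl of the 3-hydroxypropyl chain, would shift the number remains open.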